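The source may report more compounds than this note shows. Statements on the series, on what has been measured and on what is new or still open speak of the compounds shown alone.

Compound 2 `CC(C)C1CC(=O)c2s/c(=N/C3CCCCC3)oc2C1` carries cyclohexyl on the double-bonded nitrogen of the core shared with compound 1 `CC(C)C1CC(=O)c2s/c(=N/c3ccccc3)oc2C1`. In a functional assay on NUGC-3 cells (Homo sapiens) for antiproliferative activity, read by sulforhodamine B assay (on this read-out higher numbers stand for weaker inhibition of growth and lower numbers for stronger inhibition of growth), compound 2 gives 2710 nM, the second highest of the three numbers in hand; compound 1 gives 1220 nM, and compound 3 `CC1CC(=O)c2s/c(=N/c3ccc(Cl)cc3)oc2C1` gives 15900 nM. Going by the values given here, the one step read directly between neighbouring structures is a 2.2-fold higher number from compound 1 to compound 2 (0.35 log units; beyond the scatter). Compound 3 differs from compound 2 in two places at once, so its number on its own separates neither change.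

Compound 4 `CC(C)C1CC(=O)c2s/c(=N/c3ccc(F)cc3)oc2C1` differs from compound 2 by 4-fluorophenyl in place of cyclohexyl on a double-bonded nitrogen. Among the compounds with values here, the aromatic ring of compound 1 returns, with fluorine added; the only measured step bearing on this is the one from compound 1 to compound 2 taken in reverse, and what the fluorine alone contributes is not read by any measured pair. A modest fall is therefore expected, and in this assay compound 4 is expected to give 1300 nM, within the range 500 nM to 3500 nM. The step this estimate implies is expected to be a 2.1-fold lower number from compound 2 to compound 4 (0.32 log units; beyond the scatter).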

Compound 4, concentration for 50% growth inhibition: 670 nM
Estimate against measurement, compound 4: 1.9-fold (0.29 log units) above, within the range that was stated.
By their numbers in this assay, from the lowest: compounds 4 and 1 (each within the scatter of the next); then compound 2; then compound 3.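

In this assay, the double-bonded nitrogen now has a second aromatic group set against cyclohexyl: 4-fluorophenyl in place of cyclohexyl gives a 4.0-fold lower number from compound 2 to compound 4 (0.61 log units; beyond the scatter) and extends the direction of the phenyl comparison, with compounds 1 and 4 both reading lower than compound 2 and neither going against it. Fluoro in place of hydrogen on an aromatic carbon gives a 1.8-fold lower number from compound 1 to compound 4 (0.26 log units; within the scatter) and so does not separate these two compounds on this read-out. Nothing in hand explains either comparison.

Compound 3 differs from compound 4 in two places, so steps to it cannot be read. Still open, on these data alone, is how a methoxy group or an amine on the aromatic ring, or a longer alkyl chain in place of the ring on the nitrogen, would compare.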